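Inverting one ring stereocentre of compound 2

The compounds below may be only part of what the source reports. "The series", "measured", "known", "first", "only" and "open" are said of these compounds alone.

compound 1 `O=P(O)(O)OCC1CCC(COP(=O)(O)O)[C@H](COP(=O)(O)O)C1` | > 100000 nM
compound 2 `O=S(=O)(O)CC1CC[C@@H](CS(=O)(=O)O)C[C@H]1CS(=O)(=O)O` | > 100000 nM

In a functional assay on SH-SY5Y cells (Homo sapiens) (on this read-out higher numbers stand for an effect only at larger amounts of compound and lower numbers for an effect already at smaller amounts), compound 2 gives > 100000 nM as a limit and not a number. Compound 1 gives > 100000 nM as a limit too. Both therefore stand at the limit of > 100000 nM in this assay, at which 2 of the 2 values shown sit, and no ranking follows from them.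

Compound 3 `O=S(=O)(O)CC1CC[C@H](CS(=O)(=O)O)C[C@H]1CS(=O)(=O)O` differs from compound 2 as follows: the two compounds have the same atoms and bonds; at least one stereo element is drawn with a configuration in one of them and without one in the other: 1 of 3 stereo elements differ; a stereocentre at a saturated ring carbon is drawn R in compound 2 and S in compound 3.

No measured step sizes this change. With compound 2 at > 100000 nM as the only reference, no step beyond the scatter is expected in either direction in this assay. The expected change is a number no higher from compound 2 to compound 3 (the limit leaves the size open) in this estimate. For compound 3 the expected value is 100000 nM (estimated range 40000 nM to 200000 nM).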

Compound 3, half-maximal effective concentration: > 100000 nM
Compound 3: a limit, no number (the forecaster's own chance of this, stated with the estimate: 85%); the middle value lies on the limit itself.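

In this assay compound 3 gives > 100000 nM as a limit and not a number. Going by these compounds alone, compound 2 also stands at a limit, so no step between compound 2 and compound 3 can be read. The compounds shown leave open whether this ring stereocentre affects the read-out at all.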